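Acetoxy to benzoyloxy on compound 2

A few compounds are considered here, and "the series" means these few. Any claim that something is new, unique, unknown or untested is made for them only; others in the source may bear on it.

Measured in a functional assay on Ishikawa cells (Homo sapiens) for inhibition, read by MTT assay, with a stated time of 72 h, tested at 10 ug/mL; a higher number here means more inhibition of growth at the concentration tested, a lower number less inhibition of growth:
- compound 1 `C=C1[C@H](OCC(C)C)[C@@H](OC(C)=O)[C@@H](OC(C)=O)C(C)(C)/C=C/[C@@H](C)C(=O)[C@@]2(OC(C)=O)C[C@@](C)(OC(C)=O)[C@H](OC(C)=O)[C@@H]2[C@H]1OC(C)=O`: 21.4%
- compound 2 `C=C1[C@H](OC(C)=O)CC(=O)C(C)(C)/C=C/[C@@H](C)C(=O)[C@@]2(OC(C)=O)C[C@@](C)(OC(C)=O)[C@H](OC(C)=O)[C@@H]2[C@H]1OC(C)=O`: 11.6%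

Compound 2, at 11.6%, and compound 1, at 21.4%, lie within the scatter of each other. Compound 3 `C=C1[C@H](OC(C)=O)CC(=O)C(C)(C)/C=C/[C@@H](C)C(=O)[C@@]2(OC(C)=O)C[C@@](C)(OC(=O)c3ccccc3)[C@H](OC(C)=O)[C@@H]2[C@H]1OC(C)=O` keeps the core of compound 2 but carries one change, phenyl in place of methyl on a carbonyl carbon, acetoxy to benzoyloxy. Going by the values given here, no measured pair shows this change, so the data offer no precedent for its size. A small upward step in this assay is expected, none beyond the scatter. The expected step is a number 8.4 percentage points higher from compound 2 to compound 3 (within the scatter). For compound 3 the estimate is 20%, with an expected range of 6% to 45%.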

Compound 3, percent growth inhibition at one concentration: 8%
The estimate for compound 3 lay 12 percentage points above the measured number; the measured number falls inside the stated range.
By their numbers in this assay, from the lowest: compounds 3, 2 and 1 (each within the scatter of the next, the first and the last beyond it).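

In this assay, going by these compounds alone, the change from acetoxy to benzoyloxy gives a number 3.6 percentage points lower from compound 2 to compound 3 (within the scatter) and so provides the first measured pair for phenyl in place of methyl on this carbonyl carbon. At this position, a six-membered aromatic ring of carbon can therefore replace methyl without moving the read-out beyond the scatter. As far as these compounds go, whether an amine, a carboxylic acid or a longer chain on this carbonyl carbon would do the same remains open. No available measurement accounts for the result.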